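Compound 3: dropping the benzyl group from compound 1

The compounds below may be only part of what the source reports. "The series", "measured", "known", "first", "only" and "open" are said of these compounds alone.

compound 1 `COc1ccc(-c2cnc(NC(=O)c3ccc(F)cc3)n2Cc2ccccc2)cc1` gives > 100000 nM as a limit
compound 2 `Cn1c(-c2ccccc2)cnc1NC(=O)c1ccccc1` gives > 100000 nM as a limit

Both entries come from a toxicity assay on THP-1 cells (Homo sapiens) for inhibition (on this read-out higher numbers stand for lower toxicity in this test and lower numbers for higher toxicity in this test), and neither is a number. Compound 1 therefore stands at a limit, as does compound 2 (the limit of > 100000 nM in this assay, at which 2 of the 2 values shown sit). Compound 3 `COc1ccc(-c2cnc(NC(=O)c3ccc(F)cc3)[nH]2)cc1` carries hydrogen in place of benzyl on an aromatic nitrogen. Going by the values given here, no measured step is available to size this change, so no step beyond the scatter is expected in this assay and compound 3 is expected to stay near that limit. The estimated change is a number no higher from compound 1 to compound 3 (the limit leaves the size open) on this read-out. For compound 3 the estimate is 100000 nM with an expected range from 40000 nM to 150000 nM on this read-out.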

Compound 3, half-maximal cytotoxic concentration: > 100000 nM
Compound 3: only a limit was reported; the forecaster's own chance of this, stated with the estimate: 75%; the middle value sits exactly at the limit.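

Going by these compounds alone, compound 1 and compound 3 both stand as limits in this assay, so no step between them can be read: the limit of > 100000 nM in this assay, at which 3 of the 3 values shown sit.

Going by these compounds, whether hydrogen in place of benzyl on an aromatic nitrogen changes the toxicity read-out at all remains open.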